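Naphthyl pyranoside antiproliferative series: a third ring substituent

A few compounds are considered here, and "the series" means these few. Any claim that something is new, unique, unknown or untested is made for them only; others in the source may bear on it.

Measured compounds:
compound 1, `O[C@H]1[C@H](Oc2ccc3ccccc3c2)OC[C@@H](O)[C@@H]1F`, 72 uM
compound 2, `O[C@@H]1CO[C@@H](Oc2ccc3ccccc3c2)[C@H](O)C1`, 79 uM

Compound 2 has the higher of the two numbers in an ADME assay on CCD-1095SK cells (Homo sapiens) for antiproliferative activity, read by crystal violet staining, with a stated time of 96 h (a lower number here means that less compound is needed, a higher number that more compound is needed for the effect), but its nearest neighbour, compound 1, lies within the scatter of it: in this assay compound 1 gives 72 uM, and compound 2 gives 79 uM. The step from compound 1 to compound 2 was a 1.1-fold higher number from compound 1 to compound 2 (0.04 log units; within the scatter), so the two are not separated.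

Compound 3, `O[C@H]1[C@H](Oc2ccc3ccccc3c2)OC[C@@H](O)[C@H]1O`, is not yet measured in this assay. It differs from compound 2 by hydroxy in place of hydrogen on a saturated ring carbon. Within the data shown here, the only measured step that touches the same saturated ring carbon is a 1.1-fold higher number from compound 1 to compound 2 (0.04 log units; within the scatter), and it stayed within the scatter. On that basis no step beyond the scatter is expected from compound 2 to compound 3 in this assay, and the expected step is a 1.0-fold higher number from compound 2 to compound 3 (0.01 log units; within the scatter). Compound 3 is therefore estimated at 80 uM, with a range from 40 uM to 160 uM.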

Compound 3, concentration for half-maximal effect: 182 uM
Beside the measured number, compound 3's estimate is 2.3-fold (0.36 log units) below it; measured number outside the range, above it.
By their numbers in this assay, from the lowest: compounds 1 and 2 (each within the scatter of the next); then compound 3.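

In this assay, among these compounds, this saturated ring carbon proved not to be indifferent to what it carries: hydroxy in place of hydrogen gave a 2.3-fold higher number from compound 2 to compound 3 (0.36 log units; beyond the scatter), a modest step but the first in these compounds to lie beyond the scatter. The earlier step at this carbon, a 1.1-fold higher number from compound 1 to compound 2 (0.04 log units; within the scatter), had left the two compounds unseparated, so the position's response became visible only with the hydroxy group, and the change went towards needing more compound for the effect. No available measurement bears on the reason for this step.

With only hydrogen, fluoro and hydroxy shown at this carbon, the compounds leave open how a methoxy group or an amine would behave there. They also leave open whether the step would persist if the two ring atoms that each bear a hydroxy group carried something else.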